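This account rests on a few compounds, and the source may have more. Where it says the series, first, only, none or still open, it means among the compounds named here.

Measured so far:
- compound 1 `Cc1ccc(CSc2nc3nc(C)cc(Nc4ccc(C(=O)/C=C/c5ccc6ccccc6c5)cc4)n3n2)cc1`: 880 nM
- compound 2 `Cc1cc(Nc2ccc(C(=O)/C=C/c3ccc4ccccc4c3)cc2)n2nc(SCc3ccc(F)cc3)nc2n1`: 320 nM

Among the measured compounds shown here, in a functional assay on SW-620 cells (Homo sapiens) for cytotoxicity, read by MTT assay, with stated times of 4 h and 72 h, tested at 5 uM (a lower number here means a stronger inhibitor, a higher number a weaker inhibitor), compound 2 gives 320 nM, the lower of the two numbers, and its only neighbour is compound 1 at 880 nM. The next compound, compound 3 `Cc1cc(Nc2ccc(C(=O)/C=C/c3ccc4ccccc4c3)cc2)n2nc(SCc3cccc(C(F)(F)F)c3)nc2n1`, makes one structural change: 3-(trifluoromethyl)phenyl in place of 4-fluorophenyl on a saturated chain carbon bound to a sulfur. For the measured compounds named here, only one measured step bears on this: a 2.8-fold lower number from compound 1 to compound 2 (0.44 log units; beyond the scatter). There, fluoro takes the place of methyl on an aromatic carbon, in the same part of the molecule. Going by the values given here, that step is modest, and no measured compound carries trifluoromethyl, so the guidance is thin. With compound 2 holding the lower number, a small move toward a higher number in this assay is expected, no larger than the measured step. The estimated change is a 1.7-fold higher number from compound 2 to compound 3 (0.24 log units; within the scatter). For compound 3 the estimate is 550 nM, with an expected range of 180 nM to 1500 nM.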

Compound 3, half-maximal inhibitory concentration: 2070 nM
Compound 3: the middle estimate sits 3.8-fold (0.58 log units) below what was measured, outside the stated range (above it).
By their numbers in this assay, from the lowest: compound 2; then compound 1; then compound 3.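

In this assay, the aryl group on the saturated chain carbon bound to a sulfur turns out to matter in both directions: a 6.5-fold higher number from compound 2 to compound 3 (0.81 log units; beyond the scatter), a larger move than the earlier fluoro-for-methyl step and opposite in sign. Compared with the methyl-bearing group, the new group also gives a weaker result, with a 2.4-fold higher number from compound 1 to compound 3 (0.37 log units; beyond the scatter), so compound 3 is the weakest of the three, beyond the scatter against each of the others. No measurement at hand explains this loss.

The change from 4-fluorophenyl to 3-(trifluoromethyl)phenyl alters both the substituent and its printed ring number, so the compounds shown cannot say which of the two drives the result. 4-(Trifluoromethyl)phenyl and 3-fluorophenyl would separate those two changes, and an unsubstituted phenyl would give a plain reference, but none of these appears among the compounds shown.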